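From Chloro to Trifluoromethyl: One Small Step

This account rests on a few compounds, and the source may have more. Where it says the series, first, only, none or still open, it means among the compounds named here.

Measured in a functional assay on BV-2 cells (Mus musculus) for inhibition, read by Griess assay, with stated times of 3 h and 24 h (a lower number here means a stronger inhibitor, a higher number a weaker inhibitor), so far:
- compound 1 `O=S(=O)(/C=C/c1ccc(O)c(O)c1)CCc1ccccc1` gives 30600 nM
- compound 2 `O=S(=O)(/C=C/c1ccc(O)c(O)c1)Cc1ccc(Cl)cc1` gives 11700 nM

Within the data shown here, compound 2 holds the lower of the two numbers; the only measured step, a 2.6-fold lower number from compound 1 to compound 2 (0.42 log units; beyond the scatter), separates it from compound 1. Compound 3 `O=S(=O)(/C=C/c1ccc(O)c(O)c1)Cc1ccc(C(F)(F)F)cc1` differs from compound 2 by trifluoromethyl in place of chloro on an aromatic carbon. That earlier step exchanged the whole group on the sulfonyl chain, so it bears only loosely on this exchange of one group on the ring for another. The expected step is therefore small, a 1.0-fold higher number from compound 2 to compound 3 (0.01 log units; within the scatter), within the scatter. Compound 3 is expected at 12000 nM, within 5000 nM to 30000 nM.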

Compound 3, half-maximal inhibitory concentration: 15900 nM
For compound 3 the middle estimate is 1.3-fold (0.12 log units) below the measured one; low and high end bracket the measured number.
By their numbers in this assay, from the lowest: compounds 2, 3 and 1 (each within the scatter of the next, the first and the last beyond it).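

Swapping chloro for trifluoromethyl on this aromatic carbon, para to a large group, gives a 1.4-fold higher number from compound 2 to compound 3 (0.13 log units; within the scatter) in this assay. Compound 2 and compound 3 therefore cannot be told apart, so this position accepts either group with no clear loss, something the earlier step, which changed the sulfonyl chain, could not show. Nothing available here explains this result.

Still open, on these data alone, is whether an amine or a carboxylic acid at this position would shift the number beyond the scatter. A hydroxyl group there remains equally untested in the compounds shown.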